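The compounds below may be only part of what the source reports. "The series", "measured", "known", "first", "only" and "open" are said of these compounds alone.

Measured so far in a functional assay on isolated protein for inhibition of Glucose-dependent insulinotropic receptor (Rattus norvegicus), read by HTRF and cAMP accumulation; a lower number here means a smaller maximal response, a higher number a larger maximal response:
compound 1 `Cc1nc(S(C)(=O)=O)ccc1Oc1ncnc(OC2CCN(C(=O)OC3COC3)CC2)c1F` gives 66%;
compound 2 `Cc1nc(S(C)(=O)=O)ccc1Oc1ncnc(OC2CCN(C(=O)OC3(C(F)(F)F)CCC3)CC2)c1F` gives 82%;
compound 3 `Cc1nc(S(C)(=O)=O)ccc1Oc1ncnc(OC2CCN(C(=O)SC(C)C)CC2)c1F` gives 81%.

On these numbers compound 2 stands at the top, though its gap to compound 3 lies within the scatter of repeated measurements, while its gap to compound 1 lies beyond it. All three share the same core and differ only in the group attached to the carbonyl carbon of the ring nitrogen.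

Compound 4 `Cc1nc(S(C)(=O)=O)ccc1Oc1ncnc(OC2CCN(C(=O)C(C)(F)F)CC2)c1F` has not yet been measured. It differs from compound 2 as follows: a group of 4 heavy atoms (2 carbon, 2 fluorine; no ring) in place of a group of 9 heavy atoms (5 carbon, 1 oxygen, 3 fluorine; one four-membered non-aromatic ring of carbon only), on a carbonyl carbon

Two measured steps speak to this. Going from the oxetanyl ether to larger groups gave modest rises, a number 16 percentage points higher from compound 1 to compound 2 (beyond the scatter) and a number 15 percentage points higher from compound 1 to compound 3 (beyond the scatter). Yet swapping the ring-bearing group of compound 2 for a small chain without a ring gave only a number 1 percentage points lower from compound 2 to compound 3 (within the scatter), a change within the scatter. Among the compounds with values here, since compound 4 likewise carries a small group without a ring on that carbonyl carbon, the most comparable step is the one from compound 2 to compound 3, and no step beyond the scatter is expected in this assay.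

The expected value for compound 4 is therefore 78%, within a range from 64% to 90%, which amounts to an expected step of a number 4 percentage points lower from compound 2 to compound 4 (within the scatter).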

Compound 4, largest response reached (reported as efficacy), in percent of the reference or control that the assay uses: 87%
Estimate against measurement, compound 4: 9 percentage points below; low and high end bracket the measured number.
By their numbers in this assay, from the lowest: compound 1; then compounds 3, 2 and 4 (each within the scatter of the next).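

In this assay, within the data shown here, the carbonyl carbon can carry 1,1-difluoroethyl, a group with no ring and no hydrogen-bond acceptor that joins through carbon rather than through the oxygen or sulfur of the earlier compounds. The response holds up with this change, with a number 5 percentage points higher from compound 2 to compound 4 (within the scatter) and a number 6 percentage points higher from compound 3 to compound 4 (within the scatter) as the two comparisons, so among these compounds neither a ring nor a linking oxygen or sulfur on the carbonyl carbon is required for a response of this size. Compound 1, with its (oxetan-3-yl)oxy group, is the one that stands apart, with a number 21 percentage points higher from compound 1 to compound 4 (beyond the scatter) as a third comparison, but nothing available here accounts for this difference or for the tolerance of the other groups.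

The compounds shown leave open whether the two fluorines matter, which a plain ethyl group on the same carbonyl carbon would test, and whether a dimethylamino group there would fit the same picture. They also cover only the largest response reached, so how much of each compound is needed to produce that response remains an open question.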